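Compound 4: methanesulfonamido in place of trifluoromethyl

This account rests on a few compounds, and the source may have more. Where it says the series, first, only, none or still open, it means among the compounds named here.

Working notes on the series. Compound 1 `O=C([C@@H]1C[C@H]1c1ccccc1)N(CC1CCCNC1)c1ccc(-c2ccccc2)cc1` gives 10 nM in a functional assay for agonist activity at G protein-coupled receptor 88 (Homo sapiens), read by HTRF and cAMP accumulation (a lower number here means that less compound is needed, a higher number that more compound is needed for the effect), and is the lower of the two numbers in hand. Compound 2 `CC[C@H](C)[C@H](N)CN(C(=O)[C@@H]1C[C@H]1c1ccccc1Cl)c1ccc(-c2ccccc2)cc1` reports only a limit, > 25000 nM in this assay, rather than a number; this is the limit of > 25000 nM in this assay, at which 1 of the 3 values shown sits. For the measured compounds named here, compound 3 `CC[C@H](C)[C@H](N)CN(C(=O)[C@@H]1C[C@H]1c1ccccc1)c1ccc(-c2ccc(C(F)(F)F)cc2)cc1` gives 340 nM in this assay, the higher of the two numbers, and its gap to compound 1 lies beyond the scatter; the two compounds differ in more than one place, so the pair shows only its two values and no single step.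

Compound 4 `CC[C@H](C)[C@H](N)CN(C(=O)[C@@H]1C[C@H]1c1ccccc1)c1ccc(-c2ccc(NS(C)(=O)=O)cc2)cc1` is compound 3 with one change: methanesulfonamido in place of trifluoromethyl on an aromatic carbon. Going by the values given here, no measured step carries this exchange, so the expectation rests on compound 3 alone. The step from compound 3 to compound 4 in this assay is expected to be a 2.1-fold higher number from compound 3 to compound 4 (0.31 log units; beyond the scatter), a modest rise that may not clear the scatter, since the trifluoromethyl is replaced by a larger, hydrogen-bond-donating group at the same place. Compound 4 is therefore estimated at 700 nM in this assay, with a range from 150 nM to 4000 nM.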

Compound 4, half-maximal effective concentration: 1200 nM
Beside the measured number, compound 4's estimate is 1.7-fold (0.23 log units) below it; the measured number falls inside the stated range.
By their numbers in this assay, from the lowest: compound 1; then compound 3; then compound 4. At a limit, above all of these: compound 2.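

In this assay, for the compounds shown here, methanesulfonamido in place of trifluoromethyl, on an aromatic carbon para to a large group, gives a 3.5-fold higher number from compound 3 to compound 4 (0.55 log units; beyond the scatter), the only step in hand that isolates a single change and the first direct reading of this position. The step is modest, and compound 4 still returns a number rather than a limit, so this position accepts a group that brings a hydrogen-bond donor and hydrogen-bond acceptors, at some cost in the amount of compound needed. Nothing available on the two groups' properties accounts for the size of this step, so the result stands as an observation without an assigned cause.

As far as these compounds go, it remains open whether the rise follows the amide-type hydrogen of methanesulfonamido or the sulfonyl part, which a methylsulfonyl group or an N-methylated methanesulfonamido at the same place would separate, and how an amine or a carboxylic acid there would read. From the compounds shown here alone, it is also open whether the same exchange would give a step of similar size on the core of compound 1, whose nitrogen substituent differs from that of compound 3.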